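Removing One Chloro From a Weak Benzyl Ether

A few compounds are considered here, and "the series" means these few. Any claim that something is new, unique, unknown or untested is made for them only; others in the source may bear on it.

Measured compounds:
compound 1, `Cc1ccc(NC(=S)NC(=O)c2ccc(OCc3cccc(Cl)c3)cc2)cc1-c1nc2ccccc2[nH]1`, 51300 nM 
compound 2, `Cc1ccc(NC(=S)NC(=O)c2ccc(OCc3ccc(C(F)(F)F)cc3)cc2)cc1-c1nc2ccccc2[nH]1`, 6500 nM 
compound 3, `Cc1ccc(NC(=S)NC(=O)c2ccc(OCc3cccc(Cl)c3Cl)cc2)cc1-c1nc2ccccc2[nH]1`, > 100000 nM 

In a functional assay on MGC-803 cells (Homo sapiens) for inhibition, read by MTT assay, with a stated time of 48 h (on this read-out lower numbers stand for stronger inhibition and higher numbers for weaker inhibition), compound 3 sits only at a limit, (the limit of > 100000 nM in this assay, at which 1 of the 3 values shown sits), so no number is known for it. Compound 4, `Cc1ccc(NC(=S)NC(=O)c2ccc(OCc3ccccc3Cl)cc2)cc1-c1nc2ccccc2[nH]1`, differs from compound 3 by hydrogen in place of chloro on an aromatic carbon. The nearest measured step is an at least 1.9-fold higher number from compound 1 to compound 3 (0.28 log units; that floor lies within the scatter), whose floor lies within the scatter; the step of an at least 15-fold higher number from compound 2 to compound 3 (1.18 log units; beyond the scatter) was large, and a 7.9-fold lower number from compound 1 to compound 2 (0.90 log units; beyond the scatter) was modest. Taking away one chloro therefore is expected to bring at most a small change in this assay, roughly back toward compound 1. Compound 4 is expected to give 70000 nM, between 30000 nM and 150000 nM, an expected step of an at least 1.4-fold lower number from compound 3 to compound 4 (0.15 log units; that floor lies within the scatter).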

Compound 4, half-maximal inhibitory concentration: 45000 nM
Compound 4: the middle estimate sits 1.6-fold (0.19 log units) above what was measured; the range from low to high includes it.
By their numbers in this assay, from the lowest: compound 2; then compounds 4 and 1 (each within the scatter of the next). At a limit, above all of these: compound 3.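

Compound 3 stands only at a limit, yet going from 2,3-dichlorobenzyl to 2-chlorobenzyl gives a step that clears the scatter in this assay: an at least 2.2-fold lower number from compound 3 to compound 4 (0.34 log units; beyond the scatter). The 2-chlorophenyl and 3-chlorophenyl compounds cannot be told apart: a 1.1-fold lower number from compound 1 to compound 4 (0.06 log units; within the scatter). The 4-(trifluoromethyl)phenyl group also keeps a clear lead over 2-chlorophenyl: a 6.9-fold higher number from compound 2 to compound 4 (0.84 log units; beyond the scatter).

Still open, from the compounds shown here alone, is how a plain benzyl group with no chloro, or a benzyl carrying a methoxy group, would read here. Either would show whether a single chloro matters at all.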